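Swapping Bromophenyl for Methylsulfanylphenyl on the Urea Nitrogen

The compounds below may be only part of what the source reports. "The series", "measured", "known", "first", "only" and "open" are said of these compounds alone.

The compounds share a core and differ only in the aryl group on one amide-type nitrogen. In a functional assay on CRL2813 cells (Homo sapiens) for cytotoxicity, read by sulforhodamine B assay, with a stated time of 5 days (on this read-out higher numbers stand for weaker inhibition and lower numbers for stronger inhibition), compound 1 `O=C(Nc1ccc(F)cc1)N[C@H]1CC[C@H](Oc2ccc(F)cc2)CC1` gives 20000 nM. Compound 2 `O=C(Nc1cccc(F)c1)N[C@H]1CC[C@H](Oc2ccc(F)cc2)CC1` gives 8300 nM, reached through a 2.4-fold lower number from compound 1 to compound 2 (0.38 log units; beyond the scatter). Compound 3 `O=C(Nc1ccc(Br)cc1)N[C@H]1CC[C@H](Oc2ccc(F)cc2)CC1` gives > 20000 nM, which is a limit of the assay rather than a number. Compound 3 thus stands at the weak end of the three, since an at least 2.4-fold higher number from compound 2 to compound 3 (0.38 log units; beyond the scatter) lies beyond the scatter, while a number no lower from compound 1 to compound 3 (the limit leaves the size open) cannot be sized because of the limit of > 20000 nM in this assay, at which 1 of the 3 values shown sits.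

Compound 4 `CSc1ccccc1NC(=O)N[C@H]1CC[C@H](Oc2ccc(F)cc2)CC1` differs from compound 3 by 2-(methylsulfanyl)phenyl in place of 4-bromophenyl on an amide-type nitrogen. Among the measured compounds shown here, no measured step makes this exact change; a 2.4-fold lower number from compound 1 to compound 2 (0.38 log units; beyond the scatter) shows that changing 4-fluorophenyl to 3-fluorophenyl shifts the number modestly, and an at least 2.4-fold higher number from compound 2 to compound 3 (0.38 log units; beyond the scatter) shows that 4-bromophenyl gives a weaker result than 3-fluorophenyl. Compound 4 is therefore expected to stay weak, estimated at 15000 nM with a range from 5000 nM to 40000 nM. That estimate means an expected at least 1.3-fold lower number from compound 3 to compound 4 (0.12 log units; that floor lies within the scatter), no more than modest.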

Compound 4, half-maximal inhibitory concentration: > 20000 nM
Compound 4: a limit, no number; the forecaster's own chance of this, stated with the estimate: 40%; middle value at least 1.3-fold (0.12 log units) from the limit.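

In this assay compound 4 gives > 20000 nM, which is a limit of the assay and not a number. The new aryl group, 2-(methylsulfanyl)phenyl, gives a weaker result than 3-fluorophenyl on this amide-type nitrogen, with an at least 2.4-fold higher number from compound 2 to compound 4 (0.38 log units; beyond the scatter), so compound 2 remains the strongest of the four. The data give a number no lower from compound 1 to compound 4 (the limit leaves the size open), and the step to compound 4 from compound 3 cannot be read either, because these comparisons run into the assay's ceiling: the limit of > 20000 nM in this assay, at which 2 of the 4 values shown sit.

As far as these compounds go, how far compound 3 and compound 4 lie beyond that limit remains open. From the compounds shown here alone, it is also open whether an aryl group carrying an amine or a carboxylic acid on this nitrogen would give a lower number than compound 2, at 8300 nM.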